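Branched ester side chains on a shared lactone core

The source may hold more compounds than are shown below. What is called first, only, known or untested is meant among the compounds shown, and "the series" means these compounds.

Among the compounds with values here, in an assay for inhibition of 3-hydroxy-3-methylglutaryl-coenzyme A reductase (Rattus norvegicus) (on this read-out higher numbers stand for weaker inhibition and lower numbers for stronger inhibition), compound 2 `CCCCC(=O)O[C@H]1C[C@@H](C)C=C2C=C[C@H](C)[C@H](CC[C@@H]3C[C@@H](O)CC(=O)O3)C21` gives 8.7 nM, the highest of the three numbers measured so far. Compound 1 `CCC(CC)(CC)C(=O)O[C@H]1C[C@@H](C)C=C2C=C[C@H](C)[C@H](CC[C@@H]3C[C@@H](O)CC(=O)O3)C21` gives 1.4 nM and compound 3 `CCC(C)(CC)C(=O)O[C@H]1C[C@@H](C)C=C2C=C[C@H](C)[C@H](CC[C@@H]3C[C@@H](O)CC(=O)O3)C21` gives 1.4 nM. Compound 4 `CCCC(CC)(CC)C(=O)O[C@H]1C[C@@H](C)C=C2C=C[C@H](C)[C@H](CC[C@@H]3C[C@@H](O)CC(=O)O3)C21` has not yet been measured; it differs from compound 2 by 1,1-diethylbutyl in place of butyl on a carbonyl carbon. Within the data shown here, two measured steps bear on this change: a 6.2-fold lower number from compound 2 to compound 3 (0.79 log units; beyond the scatter), and a 6.2-fold higher number from compound 1 to compound 2 (0.79 log units; beyond the scatter). In both cases a branched group on the carbonyl carbon went with a modestly lower number than butyl, and compound 4 carries a branched group of the same kind, so a step of similar size is expected in this assay, a 5.8-fold lower number from compound 2 to compound 4 (0.76 log units; beyond the scatter). Compound 4 is accordingly estimated at 1.5 nM, with a range from 0.6 nM to 4 nM.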

Compound 4, half-maximal inhibitory concentration: 1.9 nM
The estimate for compound 4 lay 1.3-fold (0.10 log units) below the measured number; the measured number falls inside the stated range.
By their numbers in this assay, from the lowest: compounds 1, 3 and 4 (each within the scatter of the next); then compound 2.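

In this assay a third branched group on the carbonyl carbon, 1,1-diethylbutyl, again goes with a lower number than butyl, with a 4.6-fold lower number from compound 2 to compound 4 (0.66 log units; beyond the scatter). Among the branched groups, the steps stay within the scatter, with a 1.4-fold higher number from compound 3 to compound 4 (0.13 log units; within the scatter) and a 1.4-fold higher number from compound 1 to compound 4 (0.13 log units; within the scatter), so compound 1, compound 3 and compound 4 cannot be told apart on this read-out. Nothing given here accounts for these steps. The compounds shown leave open whether a longer straight chain such as hexyl would match these branched groups, and whether an amine on the chain would be tolerated.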